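The source may hold more compounds than are shown below. What is called first, only, known or untested is meant among the compounds shown, and "the series" means these compounds.

Working notes on the series. Within the data shown here, compound 1 `CC1=C(C(N)=O)C(c2ccsc2)NC(=O)N1` and compound 2 `CC1=C(C(=O)OC2CCCC2)C(c2ccsc2)NC(=O)N1` share one core and are the two measured members. In an assay on membranes from CHO cells for displacement of a labelled ligand from adenosine receptor A1 (Homo sapiens), read by scintillation counting, with a stated time of 60 min, tested at 1 uM (on this read-out lower numbers stand for less inhibition and higher numbers for more inhibition at the one concentration tested (going by the name of the read-out)), compound 1 gives 2%, and compound 2 gives 5%. Among the measured compounds shown here, on these two numbers compound 2 stands highest, with compound 1 nearest; the single measured step, a number 3 percentage points higher from compound 1 to compound 2 (within the scatter), is within the scatter, so the two cannot be ordered. That step exchanged cyclopentyloxy for amino on a carbonyl carbon.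

Compound 3 `CC1=C(C(=O)OCC2CC2)C(c2ccsc2)NC(=O)N1` is not yet measured. Its change from compound 2 is cyclopropylmethyl in place of cyclopentyl on an oxygen next to a carbonyl group. For the measured compounds named here, the only step at hand that bears on it is the one from compound 1 to compound 2, which also altered the group carried at this position and moved the number within the scatter only. Nothing measured shows any effect at this position beyond the scatter, so for compound 3 a step within the scatter is expected, with no set direction, meaning an expected no change at the digits printed from compound 2 to compound 3 (within the scatter). Compound 3 is therefore estimated at 5%, in the range -5% to 16%.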

Compound 3, a percentage reported as inhibition, at one concentration (the size of the read-out at that concentration, not a potency): 39%
Beside the measured number, compound 3's estimate is 34 percentage points below it; the measured number lies above the stated range.
By their numbers in this assay, from the lowest: compounds 1 and 2 (each within the scatter of the next); then compound 3.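

Among these compounds, this position is not silent in this assay: cyclopropylmethyl in place of cyclopentyl on an oxygen next to a carbonyl group gives a number 34 percentage points higher from compound 2 to compound 3 (beyond the scatter), the first step to lie beyond the scatter. Losing the amino group from the carbonyl carbon is not enough by itself, as cyclopropylmethoxy in its place gives a number 37 percentage points higher from compound 1 to compound 3 (beyond the scatter), whereas cyclopentyloxy in that same place gave a number 3 percentage points higher from compound 1 to compound 2 (within the scatter), so among these three compounds the read-out depends on which group the oxygen carries. Nothing at hand gives a reason for the gap between the cyclopentyl and cyclopropylmethyl groups.

On these data alone, it remains open whether the higher number goes with the three-membered ring, with the linking carbon or with the overall shape of the group; a cyclobutylmethyl group, a cyclopropyl group set directly on the oxygen or an open n-butyl chain would separate these readings. Also open, as far as these compounds go, is how a carboxylic acid or a substituted amine at the same carbonyl carbon would compare with compound 3.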